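Amide in place of cyclohexyl on the fused amine

A few compounds are considered here, and "the series" means these few. Any claim that something is new, unique, unknown or untested is made for them only; others in the source may bear on it.

Measured so far in an assay on HEK293 cells for negative allosteric modulation of metabotropic glutamate receptor 5 (Homo sapiens), read by FLIPR, with a stated time of 1 h; on this read-out lower numbers stand for stronger inhibition and higher numbers for weaker inhibition:
compound 1 `COc1ccccc1C#Cc1nc2c(s1)C(=O)NCC2` gives > 10000 nM
compound 2 `Fc1cccc(C#Cc2nc3c(s2)CN(C2CCC2)CC3)c1` gives 200 nM
compound 3 `C(#Cc1nc2c(s1)CN(C1CCCCC1)CC2)c1ccccc1` gives > 10000 nM

Compound 3 stands at a limit of this assay, not at a number. Compound 1 also returns a limit. Within the data shown here, only compound 2 gives a measurable value; with the limit of > 10000 nM in this assay, at which 2 of the 3 values shown sit, no ordering of compound 3 against compound 1 is possible, and compound 2 shows the only reading inside the range.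

Compound 4 `CC1CC(C(=O)N2CCc3nc(C#Cc4ccccc4)sc3C2)C1` carries (3-methylcyclobutyl)carbonyl in place of cyclohexyl on an amine nitrogen in a ring. Among the measured compounds shown here, no step between measured compounds covers this change, so the expectation rests on compound 3 sitting at the limit and compound 2 being measurable. A step of an at least 4.0-fold lower number from compound 3 to compound 4 (0.60 log units; beyond the scatter) is expected, toward stronger inhibition but uncertain. Compound 4 is estimated at 2500 nM, range 300 nM to 10000 nM.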

Compound 4, half-maximal inhibitory concentration: > 10000 nM
Compound 4 gave a limit, no number (the forecaster's own chance of this, stated with the estimate: 40%); middle value at least 4.0-fold (0.60 log units) away from the limit.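

Compound 3 and compound 4 both return a limit, not a number, in this assay, so no step can be read between them: the limit of > 10000 nM in this assay, at which 3 of the 4 values shown sit.

Going by these compounds, whether (3-methylcyclobutyl)carbonyl in place of cyclohexyl on an amine nitrogen in a ring changes inhibition at all remains open.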